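The source may hold more compounds than are shown below. What is called first, only, known or untested is meant among the compounds shown, and "the series" means these compounds.

Measured compounds:
compound 1, `Fc1cccc(-c2cn([C@@H]3CN4CCC3CC4)nn2)c1`, 519 nM in an assay on HEK293 cells for displacement of a labelled ligand from Neuronal acetylcholine receptor; alpha4/beta2 (Homo sapiens), read by scintillation counting, with a stated time of 120 min; a lower number here means a stronger inhibitor, a higher number a weaker inhibitor
compound 2, `Fc1cccc(-c2cn(C3CN4CCC3CC4)nn2)c1`, 748 nM
compound 3, `FCCCOc1cccc(-c2cn([C@H]3CN4CCC3CC4)nn2)c1`, 9010 nM

Compound 3 gives the highest number of the three, a weaker binder than compound 1 and compound 2. The step to compound 4, `Fc1cccc(-c2cn([C@H]3CN4CCC3CC4)nn2)c1`, is fluoro in place of 3-fluoropropoxy on an aromatic carbon. Among the compounds with values here, the one step measured so far, a 1.4-fold higher number from compound 1 to compound 2 (0.16 log units; within the scatter), concerns only how the configuration is drawn and is within the scatter, so it says little about the change in this assay; compound 4 shares its atoms and bonds with compound 2 and compound 1, whose values are both far lower than that of compound 3. A large fall in the number is therefore expected, a 7.5-fold lower number from compound 3 to compound 4 (0.88 log units; beyond the scatter). Compound 4 is estimated at 1200 nM, between 450 nM and 3200 nM.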

Compound 4, inhibition constant: 5200 nM
The estimate for compound 4 lay 4.3-fold (0.64 log units) below the measured number, outside the stated range (above it).
By their numbers in this assay, from the lowest: compounds 1 and 2 (each within the scatter of the next); then compounds 4 and 3 (each within the scatter of the next).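

In this assay, the fluoro and 3-fluoropropoxy compounds, both drawn R, cannot be told apart: a 1.7-fold lower number from compound 3 to compound 4 (0.24 log units; within the scatter). The larger gaps appear at the stereocentre on the saturated ring carbon, where the atoms and bonds stay the same: a 10-fold higher number from compound 1 to compound 4 (1.00 log units; beyond the scatter), and a 7.0-fold higher number from compound 2 to compound 4 (0.84 log units; beyond the scatter). At this aromatic carbon, then, the change of group shows no effect beyond the scatter in the R series, whereas the drawn configuration does.

Going by these compounds, whether the 3-fluoropropoxy chain would behave the same way on the S form remains open. So does the effect of an amine or a carboxylic acid at this aromatic carbon.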